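Shifting the chlorine around the outer ring of a sulfonamide acid

This account rests on a few compounds, and the source may have more. Where it says the series, first, only, none or still open, it means among the compounds named here.

Compound 1 `CCCCCCCCS(=O)(=O)Nc1cc(-c2ccccc2Cl)ccc1C(=O)O` gives 26900 nM in an assay on mitochondria (strain BALB/c) for inhibition of glycerol-3-phosphate acyltransferase 1, mitochondrial (Mus musculus), read by scintillation counting, with a stated time of 10 min; a higher number here means a weaker inhibitor, a lower number a stronger inhibitor.
Compound 2 `CCCCCCCCS(=O)(=O)Nc1cc(-c2cccc(Cl)c2)ccc1C(=O)O` gives 13800 nM in this assay.

Both compounds share a core in which an octylsulfonyl amide and a carboxy group sit on a central ring that carries a chlorophenyl group; only the position of the chlorine on that outer ring differs. Going by the values given here, the only step measured so far, a 1.9-fold lower number from compound 1 to compound 2 (0.29 log units; within the scatter), moves the chlorine from the 2-position to the 3-position, and that step is within the usual scatter, so compound 1 and compound 2 stand on a par in this assay.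

Compound 3 `CCCCCCCCS(=O)(=O)Nc1cc(-c2ccc(Cl)cc2)ccc1C(=O)O` continues the same idea: 4-chlorophenyl in place of 3-chlorophenyl on an aromatic carbon. Among the compounds with values here, no measured step covers a move from the 3-position to the 4-position, and the one step that bears on it at all, a 1.9-fold lower number from compound 1 to compound 2 (0.29 log units; within the scatter), was too small to show any trend. The expectation is therefore a step of no clear size beyond the scatter, with the estimate for the change from compound 2 to compound 3 given as a 1.3-fold lower number from compound 2 to compound 3 (0.10 log units; within the scatter). Compound 3 is expected to give about 11000 nM in this assay, with a likely range from 4000 nM to 30000 nM.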

Compound 3, half-maximal inhibitory concentration: 18100 nM
Compound 3: the middle estimate sits 1.6-fold (0.22 log units) below what was measured, within the range that was stated.
By their numbers in this assay, from the lowest: compounds 2, 3 and 1 (each within the scatter of the next).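

With 4-chlorophenyl in place, all three chlorophenyl isomers can now be compared, and the new compound does not separate from either of the other two in this assay. Swapping 3-chlorophenyl for 4-chlorophenyl gives a small step (a 1.3-fold higher number from compound 2 to compound 3 (0.12 log units; within the scatter)), and swapping 2-chlorophenyl for 4-chlorophenyl gives another (a 1.5-fold lower number from compound 1 to compound 3 (0.17 log units; within the scatter)); like the earlier step, both are within the scatter, so across these three compounds the place of the chlorine on the outer ring makes no difference that can be told from repeat-measurement noise. No outside information bears on this result, so nothing can be said about what lies behind it.

These three compounds show only that moving one chlorine around this ring changes little, and they say nothing about other groups on the ring, such as a methoxy group, a nitrile or a carboxylic acid, or about a plain phenyl ring with no chlorine at all. Going by these compounds, whether a shorter or longer chain in place of the octyl chain would shift the number beyond the scatter also remains open.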